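This account rests on a few compounds, and the source may have more. Where it says the series, first, only, none or still open, it means among the compounds named here.

Values in a functional assay on DU-145 cells (Homo sapiens) for inhibition, read by trypan blue exclusion, with a stated time of 96 h; on this read-out higher numbers stand for weaker inhibition of growth and lower numbers for stronger inhibition of growth:
Compound 1 `O=C(/C(=C\c1c(O)cc(O)cc1O)SCc1ccc(Cl)cc1)c1ccc(Cl)cc1`: > 100000 nM, a limit
Compound 2 `Cc1ccc(S/C(=C/c2c(O)cc(O)cc2O)C(=O)c2ccc(Cl)cc2)cc1`: > 100000 nM, a limit
Compound 3 `O=C(/C(=C\c1c(O)cc(O)cc1O)S(=O)(=O)c1ccc(Br)cc1)c1ccc(Cl)cc1`: > 100000 nM, a limit

Compound 2 has no exact number, only a limit, and the other two compounds are in the same position: the limit of > 100000 nM in this assay, at which 3 of the 3 values shown sit. The unmeasured compound 4 `Cc1ccc(S/C(=C/c2c[nH]c3ccccc23)C(=O)c2ccc(Cl)cc2)cc1` differs from compound 2 in one group: 1H-indol-3-yl in place of 2,4,6-trihydroxyphenyl on a double-bonded chain carbon bound to a double-bonded chain carbon. The three measured steps are a step that the two limits leave unreadable from compound 1 to compound 2, a step that the two limits leave unreadable from compound 2 to compound 3 and a step that the two limits leave unreadable from compound 1 to compound 3. None of them replaces the 2,4,6-trihydroxyphenyl group, and none has a readable size, so they offer no size to carry over. The expectation therefore rests on the structural change alone. Replacing this whole group may shift this assay toward lower numbers, meaning stronger inhibition of growth, although compound 4 could also end up reported only as a limit. The expected change is an at least 3.3-fold lower number from compound 2 to compound 4 (0.52 log units; beyond the scatter), a rough estimate. For compound 4 the estimated value is 30000 nM, with an expected range from 3000 nM to 200000 nM.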

Compound 4, concentration for 50% growth inhibition: 10000 nM
Compound 4: middle estimate off by 3.0-fold (0.48 log units), on the high side; low and high end bracket the measured number.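

In this assay the change to 1H-indol-3-yl in place of 2,4,6-trihydroxyphenyl gives an at least 10-fold lower number from compound 2 to compound 4 (1.00 log units; beyond the scatter) and is the first step shown with a readable size, so this place can alter growth inhibition while the rest of the structure stays the same. On these data alone, compound 2 carries only a limit, so this step is a minimum and its full size stays unknown. The earlier changes all kept 2,4,6-trihydroxyphenyl, and their steps cannot be read because those compounds all sit at a limit: the limit of > 100000 nM in this assay, at which 3 of the 4 values shown sit.

The compounds shown leave open whether a plain phenyl or a 1-methyl-1H-indol-3-yl group on this carbon would lower the number as well. As far as these compounds go, it is also open whether the 4-chlorobenzyl sulfanyl or 4-bromophenyl sulfonyl groups would change the value when paired with 1H-indol-3-yl.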